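This account rests on a few compounds, and the source may have more. Where it says the series, first, only, none or still open, it means among the compounds named here.

Working notes on the urea series. The shared core carries an aryl group on one urea nitrogen and a methyl-benzyl carbon on the other. In an ADME assay on the whole organism with Oryza sativa as the target, tested at 1 uM (a lower number here means a stronger effect, a higher number a weaker effect of the compound at the concentration tested), compound 1 `CCc1cccc(NC(=O)N[C@H](C)c2ccccc2)c1` gives 71%, compound 2 `CCCCc1ccc(NC(=O)N[C@H](C)c2ccccc2)cc1` gives 32% and compound 3 `CCCCc1ccc(NC(=O)N[C@@H](C)c2ccccc2)cc1` gives 72%.

Compound 2 stands lowest of the three numbers; compound 1 lies nearest, higher and beyond the scatter, and compound 3 lies furthest, also higher and beyond the scatter. Within the data shown here, the only single-point step measured so far is a number 40 percentage points higher from compound 2 to compound 3 (beyond the scatter), which arises because of the fact that compounds 2 and 3 differ only in the configuration as drawn. Compound 1 and compound 2 differ in more than one place, so their values are simply noted side by side.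

Compound 4 `CCOC(=O)c1ccc(NC(=O)N[C@H](C)c2ccccc2)cc1` is the next member. Relative to compound 2 the change is ethoxycarbonyl in place of butyl on an aromatic carbon.

Among the measured compounds shown here, no measured step bears on this change: the one step available concerns configuration only, and no substituent replacement on the aromatic ring has yet been measured in this assay. No direction is therefore anticipated with confidence, and a wide range is appropriate.

For compound 4 the expected value in this assay is 55%, with a range from 25% to 85%. The expected step is a number 23 percentage points higher from compound 2 to compound 4 (beyond the scatter).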

Compound 4, a percentage reported as activity, at one concentration (the size of the read-out at that concentration, not a potency): 100%
Estimate against measurement, compound 4: 45 percentage points below; measured number above the stated range.
By their numbers in this assay, from the lowest: compound 2; then compounds 1 and 3 (each within the scatter of the next); then compound 4.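

In this assay, ethoxycarbonyl in place of butyl on an aromatic carbon, para to a large group, gives a number 68 percentage points higher from compound 2 to compound 4 (beyond the scatter) and so shows a large step from a change of substituent alone. Among these compounds, until now, the only single-place step at hand concerned configuration; this one shows that the read-out also responds strongly to what sits at this ring position when the configuration as drawn stays the same, with compound 4 at 100% giving the weakest effect of the four compounds at the concentration tested. The information at hand offers no explanation for this step, as what is known concerns configuration and not this substituent change.

The change removes a plain chain and brings in a carbonyl and two hydrogen-bond acceptors all at once, so the compounds shown do not separate these features, and a carboxylic acid, an amine or a chain longer than butyl at the same place would help to do so. On these data alone, it also remains open whether the configuration step seen with butyl holds when ethoxycarbonyl occupies this position.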